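The compounds below may be only part of what the source reports. "The series", "measured", "known", "first", "only" and "open" are said of these compounds alone.

Measured compounds:
- compound 1 `Cc1ccc(C(=O)N2N=C(c3ccc(N4CCN(C)CC4)cc3)CC2c2ccc(N(C)C)cc2)cc1`, in a functional assay on HCC1806 cells (Homo sapiens) for inhibition, read by sulforhodamine B assay, tested at 10 uM (a lower number here means less inhibition, a higher number more inhibition at the concentration tested (going by the name of the read-out)), compound 1 gives -2.5%
- compound 2 `CN1CCN(c2ccc(C3=NN(C(=O)c4ccc(F)cc4)C(c4ccc(N(C)C)cc4)C3)cc2)CC1`, compound 2 gives 31.8%
- compound 3 `Cc1ccc(S(=O)(=O)N2N=C(c3ccc(-n4cncn4)cc3)CC2c2ccc(N(C)C)cc2)cc1`, compound 3 gives 27.7%

Compounds 1 and 2 differ in one place, (fluoro in place of methyl on an aromatic carbon), and the step is a number 34.3 percentage points higher from compound 1 to compound 2 (beyond the scatter). Compound 4 `CN(C)c1ccc(C2CC(c3ccc(-n4cncn4)cc3)=NN2S(=O)(=O)c2ccc(F)cc2)cc1` carries the same change against compound 3, (fluoro in place of methyl on an aromatic carbon); both place lines read alike, so this is the same change on the other core. How the core of compound 3 differs from that of compound 1 is not broken down here; the values of compound 3 and compound 2 lie within the scatter of each other.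

The step from compound 3 to compound 4 is expected to be a number 20.3 percentage points higher from compound 3 to compound 4 (beyond the scatter), upward because of a number 34.3 percentage points higher from compound 1 to compound 2 (beyond the scatter), yet smaller, since the cores are not shown to behave alike. Compound 4 is estimated at 48%, between 22% and 74%.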

Compound 4, a percentage reported as inhibition, at one concentration (the size of the read-out at that concentration, not a potency): 24.1%
The estimate for compound 4 lay 23.9 percentage points above the measured number; the measured number falls inside the stated range.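

Fluoro in place of methyl does not carry a fixed step from one core to the other in this assay: the same change on two cores in this assay, a number 34.3 percentage points higher (beyond the scatter) from compound 1 to compound 2 and a number 3.6 percentage points lower (within the scatter) from compound 3 to compound 4, 37.9 percentage points apart, beyond the scatter of two such steps. On the core of compound 3 the change reads a number 3.6 percentage points lower from compound 3 to compound 4 (within the scatter), so the large step seen on the other core does not transfer to this one. With a single pair on each core, this does not show which difference between the cores goes with the gap, nor how the change would behave on any further core.

Open, on these data alone, is how a chloro, a methoxy or an amine on that same aromatic carbon would read on each core. Also open, as far as these compounds go, is whether the two cores would part in the same way with those groups, and a single tested concentration gives no potency for either core.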